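The source may hold more compounds than are shown below. What is called first, only, known or untested is meant among the compounds shown, and "the series" means these compounds.

In a functional assay, with a stated time of 6 min (a lower number here means a stronger inhibitor, a higher number a weaker inhibitor), three compounds with a shared core have been measured. Compound 1 `CCCCCCCCCCCCCCCCNCn1nc(-c2ccc3c(c2)OCCO3)oc1=S` gives 22900 nM. Compound 2 `Fc1cccc(NCn2nc(-c3ccc4c(c3)OCCO4)oc2=S)c1` gives 6620 nM, and compound 3 `FC(F)(F)c1cccc(NCn2nc(-c3ccc4c(c3)OCCO4)oc2=S)c1` gives 7620 nM. Compound 2 and compound 3 therefore sit within the scatter of each other, while the number for compound 1 is clearly higher than that for compound 2.

Compound 4 `S=c1oc(-c2ccc3c(c2)OCCO3)nn1CNc1cc(Cl)ccc1Cl` has not yet been measured. It carries 2,5-dichlorophenyl in place of 3-fluorophenyl on an amine nitrogen. Going by the values given here, only one measured step bears on this change, trifluoromethyl in place of fluoro on an aromatic carbon, and it is small: a 1.2-fold higher number from compound 2 to compound 3 (0.06 log units; within the scatter). Among the compounds with values here, no measured compound carries chlorine, so this single step is weak guidance. On that evidence, no change beyond the scatter is expected in this assay, in either direction. The expected step is a 1.1-fold higher number from compound 2 to compound 4 (0.02 log units; within the scatter). For compound 4 the estimated value is 7000 nM, with an expected range from 3000 nM to 16000 nM.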

Compound 4, half-maximal inhibitory concentration: 5420 nM
Beside the measured number, compound 4's estimate is 1.3-fold (0.11 log units) above it, within the range that was stated.
By their numbers in this assay, from the lowest: compounds 4, 2 and 3 (each within the scatter of the next); then compound 1.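

In this assay, 2,5-dichlorophenyl in place of 3-fluorophenyl on an amine nitrogen gives a 1.2-fold lower number from compound 2 to compound 4 (0.09 log units; within the scatter). This is the first chlorine-bearing group shown at this position, and the step shows that a ring carrying two chlorine atoms leaves the number within the scatter of compound 2, as does trifluoromethyl in place of fluoro, with a 1.2-fold higher number from compound 2 to compound 3 (0.06 log units; within the scatter). Among these two steps, then, the aromatic substituents compared on this ring separate from compound 2 by no more than the scatter, and nothing available accounts for that result.

The compounds shown leave open what an unsubstituted phenyl ring, a methoxy group or a carboxylic acid on the ring would give at this position. They also leave open how a shorter alkyl chain on the amine nitrogen would compare, and what any change to the shared core would do.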